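Swapping the Ring on the Thiocarbonyl Carbon

The compounds below may be only part of what the source reports. "The series", "measured", "known", "first", "only" and "open" are said of these compounds alone.

Measured compounds in a functional assay on SW480 cells (Homo sapiens) for antiproliferative activity, read by MTT assay, with a stated time of 72 h; a lower number here means a stronger inhibitor, a higher number a weaker inhibitor:
Compound 1 `O=c1cc(CSC(=S)N2CCCC2)oc2cc(Cl)ccc12` gives > 25000 nM, a limit of the assay rather than a number.
Compound 2 `O=c1cc(CSC(=S)N2CCOCC2)oc2cc(Cl)ccc12` gives > 25000 nM, again only a limit.
Compound 3 `O=c1c(Cl)c(CSC(=S)N2CCCC2)oc2ccccc12` gives 1400 nM.

Compound 1 and compound 2 share one core and differ by morpholin-4-yl in place of pyrrolidin-1-yl on a thiocarbonyl carbon. Because the two values sit at the limit of > 25000 nM in this assay, at which 2 of the 3 values shown sit, the step that the two limits leave unreadable from compound 1 to compound 2 has no readable size. Compound 3 has the same atoms as compound 1 joined differently; the difference between the two cores is not broken down here. Compound 3 is the only one of the three with a number rather than a limit in this assay.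

Compound 4 `O=c1c(Cl)c(CSC(=S)N2CCOCC2)oc2ccccc12` has not yet been measured in this assay. It differs from compound 3 by morpholin-4-yl in place of pyrrolidin-1-yl on a thiocarbonyl carbon, the same change as from compound 1 to compound 2. That earlier step gives no size to lean on, so the expectation for compound 4 rests only on compound 3 and its value 1400 nM, with wide uncertainty. The step from compound 3 to compound 4 is expected to be a 1.8-fold higher number from compound 3 to compound 4 (0.25 log units; within the scatter). Compound 4 is estimated at 2500 nM, between 700 nM and 12000 nM.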

Compound 4, half-maximal inhibitory concentration: 1800 nM
Beside the measured number, compound 4's estimate is 1.4-fold (0.14 log units) above it, within the range that was stated.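

On the core of compound 3, morpholin-4-yl in place of pyrrolidin-1-yl gives a 1.3-fold higher number from compound 3 to compound 4 (0.11 log units; within the scatter) in this assay, so on this core the measurement does not tell the two rings apart. The same change on the core of compound 1 cannot be read, because compound 1 and compound 2 both give an assay limit rather than a number: the limit of > 25000 nM in this assay, at which 2 of the 4 values shown sit.

One step with a size and one without cannot be compared, so nothing here shows whether the change behaves alike on the two cores. The result holds for a single pair of compounds and is no general rule for this series.

Still open, from the compounds shown here alone, is whether other groups on the thiocarbonyl carbon, such as piperidin-1-yl or an open-chain diethylamino group, would give numbers close to those of compound 3 and compound 4. Also open, going by these compounds, is which feature of the core of compound 3 sets its numbers apart from the limits seen on the core of compound 1.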